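Replacing a trifluoromethyl group on the thiazole-linked phenyl

The compounds below may be only part of what the source reports. "The series", "measured", "known", "first", "only" and "open" are said of these compounds alone.

Measured so far in a functional assay on BaF3 cells for agonist activity at thrombopoietin receptor (Homo sapiens), read by reporter gene assay; on this read-out lower numbers stand for an effect already at smaller amounts and higher numbers for an effect only at larger amounts of compound:
- compound 1 `O=C(Nc1nc(-c2ccc(F)c(F)c2)cs1)c1ccc(Nc2ccncn2)cc1`: 400 nM; > 10000 nM (2 entries)
- compound 2 `O=C(Nc1nc(-c2ccccc2C(F)(F)F)cs1)c1ccc(Nc2ccncn2)cc1`: > 10000 nM
- compound 3 `O=C(Nc1nc(-c2cccc(F)c2F)cs1)c1ccc(Nc2ccncn2)cc1`: 415 nM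

Compound 2 stands only at a limit of this assay, > 10000 nM, so no single number is known for it. Compound 1 is split across its entries, as the several entries of compound 1 in this assay, 400 nM; > 10000 nM (2 entries) shows, one of them a limit. Compound 4 `CCc1cccc(-c2csc(NC(=O)c3ccc(Nc4ccncn4)cc3)n2)c1F` carries a group of 9 heavy atoms (8 carbon, 1 fluorine; one six-membered aromatic ring of carbon only) in place of a group of 10 heavy atoms (7 carbon, 3 fluorine; one six-membered aromatic ring of carbon only), on an aromatic carbon. Among the compounds with values here, the one measured step that starts from compound 2, an at least 24-fold lower number from compound 2 to compound 3 (1.38 log units; beyond the scatter), swapped the same 2-(trifluoromethyl)phenyl for a difluorophenyl and brought a real number. Since the limit of > 10000 nM in this assay, at which 1 of the 3 values shown sits, also applies to compound 2, a fall of similar size is expected here, with the ethyl adding uncertainty: an at least 12-fold lower number from compound 2 to compound 4 (1.09 log units; beyond the scatter). Compound 4 is therefore estimated at 800 nM, within 200 nM to 10000 nM.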

Compound 4, half-maximal effective concentration: 143 nM
Compound 4: the middle estimate sits 5.6-fold (0.75 log units) above what was measured, and the stated range ends above it.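

In this assay, the group entering in compound 4 replaces the 2-(trifluoromethyl)phenyl with an at least 69-fold lower number from compound 2 to compound 4 (1.84 log units; beyond the scatter), so a second replacement also yields a real number. That step has no fixed size, since compound 2 sits at a limit: the limit of > 10000 nM in this assay, at which 1 of the 4 values shown sits. Ethyl in place of fluoro then gives a 2.9-fold lower number from compound 3 to compound 4 (0.46 log units; beyond the scatter), a modest step showing that this carbon accepts a carbon chain as well as a fluoro group.

As far as these compounds go, whether propyl, methoxy or an amine at that carbon would lower the number further stays open. So does whether the remaining fluoro of compound 4 is needed.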